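The source may report more compounds than this note shows. Statements on the series, on what has been measured and on what is new or still open speak of the compounds shown alone.

Compound 1 `CN(CCNCc1cn(-c2ccc(Cl)cc2)nn1)CCNc1ccnc2cc(Cl)ccc12`: 9500 nM
Compound 2 `CN(CCNCc1cn(-c2ccnc3cc(Cl)ccc23)nn1)CCNc1ccnc2cc(Cl)ccc12`: 18000 nM

In a functional assay on HCC827 cells (Homo sapiens) for antiproliferative activity, read by sulforhodamine B assay, with a stated time of 72 h (on this read-out higher numbers stand for weaker inhibition and lower numbers for stronger inhibition), compound 1 gives 9500 nM while compound 2 gives 18000 nM. Of the two numbers, that of compound 1 is the lower, yet the step of a 1.9-fold higher number from compound 1 to compound 2 (0.28 log units; within the scatter) lies within the scatter, so the two compounds are not separated. Compound 3 `CN(CCNCc1cn(CCCn2nn[nH]c2=O)nn1)CCNc1ccnc2cc(Cl)ccc12` has not been measured yet. It differs from compound 1 as follows: a group of 9 heavy atoms (4 carbon, 4 nitrogen, 1 oxygen; one five-membered aromatic ring with 4 hetero atoms) in place of a group of 7 heavy atoms (6 carbon, 1 chlorine; one six-membered aromatic ring of carbon only), on an aromatic nitrogen. Among the compounds with values here, the only step that bears on this is the one from compound 1 to compound 2, which also swapped the group on that aromatic nitrogen and was within the scatter. The new group here, however, is not an aromatic ring of carbon only but a five-membered ring with four hetero atoms, so the earlier step is only a loose guide. No change beyond the scatter is expected; the step of a 1.6-fold higher number from compound 1 to compound 3 (0.20 log units; within the scatter) is the estimate. Compound 3 is therefore expected to give 15000 nM, between 5000 nM and 50000 nM.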

Compound 3, half-maximal inhibitory concentration: > 200000 nM
Compound 3: a limit, no number (the forecaster's own chance of this, stated with the estimate: 15%); middle value at least 13-fold (1.12 log units) from the limit.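

Compound 3 sits at a limit of this assay, which is a bound and not a number: the limit of > 200000 nM in this assay, at which 1 of the 3 values shown sits. Within the data shown here, compounds 1 and 2 showed only that one aromatic group could replace another on this aromatic nitrogen with no separable change, as a 1.9-fold higher number from compound 1 to compound 2 (0.28 log units; within the scatter) shows. The new group, with its five-membered aromatic ring with 4 hetero atoms, gives a far larger shift, with an at least 21-fold higher number from compound 1 to compound 3 (1.32 log units; beyond the scatter) and an at least 11-fold higher number from compound 2 to compound 3 (1.04 log units; beyond the scatter), so this position does not accept every group in this assay.

This one change alters the ring, the hetero atoms and the hydrogen-bond donors and acceptors together, so the compounds shown cannot tell which of these matters. Also open, going by these compounds, is how a simple amine, a carboxylic acid or a plain phenyl ring on a carbon chain would behave at this position.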